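One Stereocentre Redrawn in a Clearance Series

The compounds below may be only part of what the source reports. "The series", "measured", "known", "first", "only" and "open" are said of these compounds alone.

Compound 1 `C[C@]1(O)C[C@](c2cccc(OC(F)(F)F)c2)([C@H](O)c2ccccn2)C1`: 117 mL/min/kg
Compound 2 `O[C@@]1(c2ccccn2)CC[C@@H](c2ccc(C(F)(F)F)cc2)C1`: 150 mL/min/kg
Compound 3 `C[C@]1(O)C[C@@](c2cccc(C(F)(F)F)c2)([C@H](O)c2ccccn2)C1`: 150 mL/min/kg

All three numbers come from an ADME assay on liver for metabolic stability, with Liver microsome (Homo sapiens) as the target, read by LC-MS, using microsomes, with a stated time of 5 h (a lower number here means slower removal, a higher number faster removal of the compound), and lie within the usual scatter of one another. Compound 2 , at 150 mL/min/kg, stands level with compound 3 , and the gap to compound 1 is also within the scatter.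

The next compound to be tested is compound 4 `O[C@@]1(c2ccccn2)CC[C@H](c2ccc(C(F)(F)F)cc2)C1`, a close relative of compound 2 . The structural change is this: the two compounds have the same atoms and bonds and differ only in configuration as drawn: 1 of 2 stereo elements differ; a stereocentre at a saturated ring carbon is drawn R in compound 2 and S in compound 4. A stereocentre is an atom whose attached groups can be arranged in space in two ways, and here a stereocentre at a saturated ring carbon is drawn R in compound 2 and S in compound 4 .

Among the compounds with values here, no measured pair here differs in this way, so the data do not show what such a change does in this assay. Within the data shown here, the only guide is how closely the three values sit, with compound 1 at 117 mL/min/kg and compound 3 at 150 mL/min/kg in the same narrow band as compound 2 . No step beyond the scatter is therefore expected. The estimated change a 1.2-fold lower number from compound 2 to compound 4 (0.06 log units; within the scatter) is small, and its direction is uncertain. The expected clearance of compound 4 is 130 mL/min/kg, within an estimated range from 80 mL/min/kg to 180 mL/min/kg in this measurement.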

Compound 4, clearance: 400 mL/min/kg
Compound 4: the middle estimate sits 3.1-fold (0.49 log units) below what was measured; measured number outside the range, above it.
By their numbers in this assay, from the lowest: compounds 1, 2 and 3 (each within the scatter of the next); then compound 4.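

In this assay, redrawing a single stereocentre at a saturated ring carbon from R to S gives a 2.7-fold higher number from compound 2 to compound 4 (0.43 log units; beyond the scatter). Compounds 1, 2 and 3 sat within the scatter of one another and no two of them differed in one place, so they gave no sign that this position could matter; now it is clear that spatial arrangement alone at this ring carbon can move clearance beyond the scatter, with the S form as drawn being removed faster in this pair. The cause of the step can be traced to one structural difference only: the fact that compounds 2 and 4 differ only in the configuration as drawn.

As far as these compounds go, how that difference acts on removal by the microsomes remains unknown, and this single pair cannot show whether the same redrawing would have a similar effect on the cores of compound 1 or compound 3, or what redrawing the second stereo element would do. Also open, from the compounds shown here alone, is whether the step would persist if an amine or a carboxylic acid took the place of the trifluoromethyl group.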